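Replacing a thiophene ring with an open-chain oxime ether

This account rests on a few compounds, and the source may have more. Where it says the series, first, only, none or still open, it means among the compounds named here.

Going by the values given here, compound 1, with the structure `Cc1ccsc1-c1ccccc1NCC1=NCCN1`, is the one compound of the pair for which a number is known. In a functional assay for activation of Alpha-1B adrenergic receptor (Homo sapiens), read by calcium flux (on this read-out lower numbers stand for an effect already at smaller amounts and higher numbers for an effect only at larger amounts of compound), compound 1 gives 112 nM. Compound 2, with the structure `Cc1cccnc1-c1ccccc1NCC1=NCCN1`, returns only a limit of the assay: in this assay compound 2 gives < 100000 nM, which is a limit and not a number. This is the limit of < 100000 nM in this assay, at which 1 of the 2 values shown sits, so the two values of the pair cannot be compared as a step, and nothing is said here about what separates them.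

Compound 3, with the structure `CC/C(=N/OC)c1ccccc1NCC1=NCCN1`, has not yet been measured. Its change from compound 1 is a group of 6 heavy atoms (4 carbon, 1 nitrogen, 1 oxygen; no ring) in place of a group of 6 heavy atoms (5 carbon, 1 sulfur; one five-membered aromatic ring with 1 hetero atom), on an aromatic carbon; the new group enters on an aromatic carbon of a six-membered aromatic ring of carbon only. Among the compounds with values here, no measured step between compounds that differ in one place is available to guide the size of this change. Compound 3 is expected to lose ground, with an estimated step of a 7.1-fold higher number from compound 1 to compound 3 (0.85 log units; beyond the scatter) that goes beyond the usual scatter. Compound 3 is estimated at 800 nM, within a range from 150 nM to 5000 nM.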

Compound 3, half-maximal effective concentration: < 5020 nM
Compound 3 ended at the assay's limit (the forecaster's own chance of this, stated with the estimate: 20%); the middle value lies beyond the limit too.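

In this assay compound 3 gives < 5020 nM, which is a limit and not a number, so the step from compound 1 to compound 3 cannot be read: the limit of < 5020 nM in this assay, at which 1 of the 3 values shown sits.

The compounds shown leave open how large a change the open-chain group of compound 3 brings in place of the 3-methylthiophen-2-yl group of compound 1.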